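The source may hold more compounds than are shown below. What is called first, only, known or untested is meant among the compounds shown, and "the series" means these compounds.

The three measured compounds share one core and differ only in the group on the six-membered aromatic ring of carbon only. Compound 1 `CC1=C(/C=C/C(=O)/C=C/c2ccccc2)C(C)(C)CCC1O` gives 5800 nM in a functional assay on LNCaP cells (Homo sapiens) for cytotoxicity, read by MTT assay, with a stated time of 72 h; on this read-out lower numbers stand for stronger inhibition and higher numbers for weaker inhibition. Compound 2 `CC1=C(/C=C/C(=O)/C=C/c2cccc(F)c2)C(C)(C)CCC1O` gives 4400 nM in this assay, and compound 3 `CC1=C(/C=C/C(=O)/C=C/c2cccc([N+](=O)[O-])c2)C(C)(C)CCC1O` gives 2000 nM in this assay. Compound 3 stands lowest of the three: the step of a 2.9-fold lower number from compound 1 to compound 3 (0.46 log units; beyond the scatter), and the step of a 2.2-fold lower number from compound 2 to compound 3 (0.34 log units; beyond the scatter), whereas the step of a 1.3-fold lower number from compound 1 to compound 2 (0.12 log units; within the scatter). Compound 4 `CCOC(OCC)c1cccc(/C=C/C(=O)/C=C/C2=C(C)C(O)CCC2(C)C)c1` carries diethoxymethyl in place of nitro on an aromatic carbon. The steps that bear on this change are the two that brought the nitro in, a 2.9-fold lower number from compound 1 to compound 3 (0.46 log units; beyond the scatter) and a 2.2-fold lower number from compound 2 to compound 3 (0.34 log units; beyond the scatter); both were modest and ran toward lower numbers, so removing the nitro is expected to give back most of that ground, and the entering diethoxymethyl has no measured counterpart among these compounds. Compound 4 is therefore expected to show a modestly higher number, a 2.5-fold higher number from compound 3 to compound 4 (0.40 log units; beyond the scatter). The estimate for compound 4 is 5000 nM, within a range from 2500 nM to 10000 nM.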

Compound 4, half-maximal inhibitory concentration: 1800 nM
Estimate against measurement, compound 4: 2.8-fold (0.44 log units) above, outside the stated range (below it).
By their numbers in this assay, from the lowest: compounds 4 and 3 (each within the scatter of the next); then compounds 2 and 1 (each within the scatter of the next).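

At this aromatic carbon, diethoxymethyl in place of nitro gives (a 1.1-fold lower number from compound 3 to compound 4 (0.05 log units; within the scatter)), so in this assay a group of more heavy atoms and no nitrogen cannot be told apart from nitro, and the low number at this place does not depend on nitro alone. The new group also stands apart from the smaller changes, with steps of (a 2.4-fold lower number from compound 2 to compound 4 (0.39 log units; beyond the scatter)) and (a 3.2-fold lower number from compound 1 to compound 4 (0.51 log units; beyond the scatter)), both modest and running the same way as the steps that brought nitro in. Nothing in hand explains why these two different groups give matching numbers.

Going by these compounds, whether an amine or a carboxylic acid on this same carbon would stay with compound 3 and compound 4 or return toward compound 1 remains open. The compounds shown also speak only to this one cell line.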